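Amino for Hydroxy: Cytotoxicity in Mouse Macrophages

A few compounds are considered here, and "the series" means these few. Any claim that something is new, unique, unknown or untested is made for them only; others in the source may bear on it.

Compound 1 `Nc1ncnc2c([C@@H]3O[C@H](CO)[C@@H](O)[C@H]3O)cn(-c3ccc(Cl)cc3)c12` and compound 2 `OC[C@H]1O[C@@H](c2cnn3c(O)ncnc23)[C@H](O)[C@@H]1O` were both tested in an ADME assay on cells (Macrophage, Mus musculus) for cytotoxicity; on this read-out higher numbers stand for lower toxicity in this test and lower numbers for higher toxicity in this test. Compound 1 gives > 64000 nM, a limit of the assay rather than a number. Compound 2 likewise gives > 64000 nM, also a limit. Compound 2 therefore sits at the limit of > 64000 nM in this assay, at which 2 of the 2 values shown sit. Compound 3 `Nc1ncnc2c([C@@H]3O[C@H](CO)[C@@H](O)[C@H]3O)cnn12` has not yet been measured; it differs from compound 2 by amino in place of hydroxy on an aromatic carbon. Among the compounds with values here, with no measured step between compounds to lean on, no change beyond the scatter is expected for a number no higher from compound 2 to compound 3 (the limit leaves the size open). Compound 3 is estimated at 64000 nM, within a range from 30000 nM to 200000 nM.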

Compound 3, half-maximal cytotoxic concentration: > 64000 nM
Compound 3: no number, only a limit; the forecaster's own chance of this, stated with the estimate: 85%; the middle value sits exactly at the limit.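

Within the data shown here, compound 2 and compound 3 both sit at a limit of the assay, so no step between them can be read. The compounds shown leave open whether amino in place of hydroxy on an aromatic carbon changes this read-out at all.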